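Swapping a Benzyl for a Phenoxy: Expected Solubility

This account rests on a few compounds, and the source may have more. Where it says the series, first, only, none or still open, it means among the compounds named here.

Measured compounds:
compound 1, `COc1ccc(F)cc1CNCCCNc1ccnc2cc(Cc3ccc(F)cc3Cl)ccc12`, solubility 4200 nM
compound 2, `Fc1ccc(Cc2ccc3c(NCCCNCc4ccco4)ccnc3c2)c(Cl)c1`, solubility 4200 nM

In a physicochemical assay for solubility, with a stated time of 18 h, at pH 7.4 (a lower number here means a less soluble compound, a higher number a more soluble compound), compound 1 gives 4200 nM. Compound 1 stands level with compound 2 at the digits shown, and the one measured step, no change at the digits printed from compound 1 to compound 2 (within the scatter), shows that exchanging the group on the saturated chain carbon bound to the amine nitrogen left the read-out within the scatter.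

Compound 3, `COc1ccc(F)cc1CNCCCNc1ccnc2cc(Oc3ccc(Cl)cc3)ccc12`, has not been measured in this assay. It differs from compound 1 by 4-chlorophenoxy in place of 2-chloro-4-fluorobenzyl on an aromatic carbon. Among the measured compounds shown here, no measured step touches this position; the step already known concerns the other end of the molecule and was within the scatter, so it bears only loosely on the new change. On that basis no step beyond the scatter is expected, and the step of no change at the digits printed from compound 1 to compound 3 (within the scatter) is estimated as flat. Compound 3 is therefore expected to give about 4200 nM, within a range of 1800 nM to 10000 nM.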

Compound 3, solubility: 14500 nM
Estimate against measurement, compound 3: 3.5-fold (0.54 log units) below; measured number above the stated range.
By their numbers in this assay, from the lowest: compounds 1 and 2 (each within the scatter of the next); then compound 3.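

Among the compounds shown here, the aromatic carbon carrying this group proved responsive in this assay where the earlier exchange at the other end of the molecule had not: 4-chlorophenoxy in place of 2-chloro-4-fluorobenzyl gave a 3.5-fold higher number from compound 1 to compound 3 (0.54 log units; beyond the scatter) as the first step beyond the scatter in this set. The change is a single exchange of groups, yet it replaces the carbon-linked ring carrying chlorine and fluorine with an oxygen-linked ring carrying chlorine alone, so this pair cannot divide the step among those differences. No available evidence explains the step.

The compounds shown leave open whether the oxygen or the altered halogen pattern accounts for the step. They also leave open how an amine or a carboxylic acid on the phenoxy ring would read out, and whether the step persists with the furan-2-yl group at the other end.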